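Swapping the aryl group on the ring nitrogen: compound 3

The compounds below may be only part of what the source reports. "The series", "measured", "known", "first", "only" and "open" are said of these compounds alone.

Measured so far:
compound 1, `CCc1ccc(-n2cc(COc3cccc(NC(=O)Nc4ccc(Cl)c(C(F)(F)F)c4)c3)nn2)cc1`, 1950 nM
compound 2, `O=C(Nc1cccc(OCc2cn(-c3cccc(Cl)c3)nn2)c1)Nc1ccc(Cl)c(C(F)(F)F)c1`, 2020 nM

Both numbers come from a functional assay on HepG2 cells (Homo sapiens) for inhibition, read by MTT assay, with a stated time of 72 h; on this read-out higher numbers stand for weaker inhibition and lower numbers for stronger inhibition. Compound 2 has the highest of the two numbers, but its nearest neighbour, compound 1, sits so close that the two cannot be told apart; the step of a 1.0-fold higher number from compound 1 to compound 2 (0.02 log units; within the scatter) is within the scatter of this assay.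

Compound 3, `O=C(Nc1cccc(OCc2cn(-c3ccccc3Br)nn2)c1)Nc1ccc(Cl)c(C(F)(F)F)c1`, has not yet been measured in this assay. It differs from compound 2 in one place: 2-bromophenyl in place of 3-chlorophenyl on an aromatic nitrogen. Within the data shown here, only one measured step bears on this kind of change, the replacement of one aryl group on the same ring nitrogen by another, from compound 1 to compound 2, and that step did not move the number beyond the scatter. The change to compound 3 is of the same kind, another aryl group on the same aromatic nitrogen, so no step beyond the scatter in this assay is expected in either direction.

Compound 3 is therefore expected to give about 2000 nM in this assay, with a range from 900 nM to 4500 nM, which means an estimated step of a 1.0-fold lower number from compound 2 to compound 3 (0.00 log units; within the scatter).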

Compound 3, half-maximal inhibitory concentration: 2810 nM
For compound 3 the middle estimate is 1.4-fold (0.15 log units) below the measured one, and the stated range covers the measured number.
By their numbers in this assay, from the lowest: compounds 1, 2 and 3 (each within the scatter of the next).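

In this assay, compound 3 brings a third aryl group onto the aromatic nitrogen of the five-membered ring, and the steps to it stay within the scatter, both for 2-bromophenyl in place of 3-chlorophenyl (a 1.4-fold higher number from compound 2 to compound 3 (0.14 log units; within the scatter)) and for 2-bromophenyl in place of 4-ethylphenyl (a 1.4-fold higher number from compound 1 to compound 3 (0.16 log units; within the scatter)). The earlier pair showed only that an ethyl and a chlorine on the phenyl ring could be exchanged at this position; compound 3 extends this to a different halogen, bromine, at a different ring position, so the three compounds cannot be told apart in this assay despite these differences. No independent measurement is available to explain why these aryl groups give numbers so alike.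

Because the bromine differs from the chlorine in both identity and ring position, this pair cannot separate the two changes, and 3-bromophenyl or 2-chlorophenyl would be needed to do so. As far as these compounds go, all three groups are substituted phenyl rings, so it stays open whether a plain butyl chain on that nitrogen, or a phenyl ring carrying an amine or a carboxylic acid, would keep the number in this range.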